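From chloro to amino on a weak compound

This account rests on a few compounds, and the source may have more. Where it says the series, first, only, none or still open, it means among the compounds named here.

In a functional assay on MOLT-4 cells (Homo sapiens) for antiproliferative activity (a lower number here means a stronger inhibitor, a higher number a weaker inhibitor), compound 1 `COC1=C(OC)/C(=C/Cn2cnc3c(Cl)ncnc32)OC1=O` gives 5970 nM. Compound 2 `COC1=C(OCc2ccc([N+](=O)[O-])cc2)/C(=C\Cn2cnc3c(Cl)ncnc32)OC1=O` gives 7350 nM, a value within the usual scatter of the first. Compound 3 `COC1=C(OC)C(O)(CCn2cnc3c(Cl)ncnc32)OC1=O` stands apart from this pair, with a reading of > 120000 nM, which is a limit of the assay and not a number.

Compound 4 `COC1=C(OC)C(O)(CCn2cnc3c(N)ncnc32)OC1=O` differs from compound 3 in one place: amino in place of chloro on an aromatic carbon. This is amino in place of chloro on an aromatic carbon. All three measured compounds carry the chloro, so none of them shows directly what this swap does.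

The expectation therefore starts from compound 3, whose reading of > 120000 nM is a limit. The swap is not expected to bring compound 4 close to the first two compounds. The expected step of an at least 1.2-fold lower number from compound 3 to compound 4 (0.07 log units; that floor lies within the scatter) is small, and any movement would be towards slightly stronger inhibition. The estimated value for compound 4 is 100000 nM, within an expected range of 30000 nM to 200000 nM.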

Compound 4, half-maximal inhibitory concentration: > 120000 nM
Compound 4 ended at the assay's limit; the forecaster's own chance of this, stated with the estimate: 70%; middle value at least 1.2-fold (0.07 log units) from the limit.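

Going by these compounds alone, compound 3 and compound 4 both end at a limit of the assay and not at a number, so no step between them can be read: the limit of > 120000 nM in this assay, at which 2 of the 4 values shown sit. Still open, from the compounds shown here alone, is what amino in place of chloro on an aromatic carbon does to a compound with a readable value.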